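From carboxy to carboxymethyl at the assay limit

This account rests on a few compounds, and the source may have more. Where it says the series, first, only, none or still open, it means among the compounds named here.

Compound 1 `Nc1nc2[nH]c(CCCCCC(=O)N[C@@H](CCC(=O)O)C(=O)O)cc2c(=O)[nH]1`: > 1000 nM (a limit)
Compound 2 `Nc1nc2[nH]c(CCCCCC(=O)O)cc2c(=O)[nH]1`: > 1000 nM (a limit)

In a functional assay on D4 cells (Cricetulus griseus) for inhibition, read by CellTiter-Blue, with a stated time of 96 h, in the presence of a further agent that is not named here (on this read-out lower numbers stand for stronger inhibition and higher numbers for weaker inhibition), compound 2 gives > 1000 nM, which is a limit of the assay and not a number. Compound 1 gives > 1000 nM in this assay, also a limit. Together these make up the whole picture so far: the limit of > 1000 nM in this assay, at which 2 of the 2 values shown sit. No actual number is therefore known for either compound, and no step size can be read from them.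

Compound 3 `Nc1nc2[nH]c(CCCCCCC(=O)O)cc2c(=O)[nH]1` has not yet been measured. It differs from compound 2 as follows: carboxymethyl in place of carboxy on a saturated chain carbon, five bonds along the chain from an aromatic carbon. Carboxymethyl stands in place of carboxy on a saturated chain carbon, five bonds along the chain from an aromatic carbon.

No change beyond the scatter is expected in this assay. The expected size of the change is a step that the limit leaves unreadable from compound 2 to compound 3. This expectation rests on compound 2, with its > 1000 nM, a limit. A report of only a limit is the likeliest outcome. For compound 3 the estimated value is 1500 nM, with an expected range from 800 nM to 3000 nM.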

Compound 3, half-maximal inhibitory concentration: > 1000 nM
Compound 3: no number, only a limit; the forecaster's own chance of this, stated with the estimate: 85%; the middle value does not contradict the limit.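

In this assay compound 3 gives > 1000 nM, which is a limit and not a number. Compound 2 also stands at a limit, so no step can be read between compound 2 and compound 3. Whether carboxymethyl in place of carboxy makes any difference in this series stays open, since all values sit at one limit: the limit of > 1000 nM in this assay, at which 3 of the 3 values shown sit.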